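Swapping the Sulfonyl for a Carbonyl in Compound 1

The source may hold more compounds than are shown below. What is called first, only, known or untested is meant among the compounds shown, and "the series" means these compounds.

Going by the values given here, compound 1 `Cc1cc(C)c(S(=O)(=O)N[C@@H](CNC(=O)CO[C@@H]2C[C@@H](CNc3ccccn3)N(C(=O)OCc3ccccc3)C2)C(=O)O)c(C)c1` gives 3.7 nM in an assay on a protein complex for inhibition of integrin alpha-5/beta-1 (Homo sapiens), read by ELISA (a higher number here means a weaker inhibitor, a lower number a stronger inhibitor), the lowest of the three numbers measured so far. Compound 3 `COC(=O)N1C[C@H](OCC(=O)NC[C@H](NS(=O)(=O)c2c(C)cc(C)cc2C)C(=O)O)C[C@H]1CNc1ccccn1` gives 15 nM, and compound 2 `Cc1cc(C)c(S(=O)(=O)N[C@@H](CNC(=O)CO[C@H]2CN[C@H](CNc3ccccn3)C2)C(=O)O)c(C)c1` gives 286 nM. Compound 4 `Cc1cc(C)c(C(=O)N[C@@H](CNC(=O)CO[C@@H]2C[C@@H](CNc3ccccn3)N(C(=O)OCc3ccccc3)C2)C(=O)O)c(C)c1` differs from compound 1 in a single place: (2,4,6-trimethylphenyl)carbonyl in place of (2,4,6-trimethylphenyl)sulfonyl on an amine nitrogen. Among the compounds with values here, none of the measured steps concerns this nitrogen: a 77-fold higher number from compound 1 to compound 2 (1.89 log units; beyond the scatter) and a 19-fold lower number from compound 2 to compound 3 (1.28 log units; beyond the scatter) alter the amine nitrogen in the ring, while a 4.1-fold higher number from compound 1 to compound 3 (0.61 log units; beyond the scatter) alters the saturated chain carbon bound to an oxygen. Within the data shown here, the expectation for compound 4 therefore rests on no directly comparable step and is uncertain. The step from compound 1 is estimated as an 11-fold higher number from compound 1 to compound 4 (1.03 log units; beyond the scatter). Compound 4 is expected to give 40 nM, within a range from 8 nM to 300 nM.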

Compound 4, half-maximal inhibitory concentration: 3.5 nM
Compound 4: middle estimate off by 11-fold (1.06 log units), on the high side; measured number outside the range, below it.
By their numbers in this assay, from the lowest: compounds 4 and 1 (each within the scatter of the next); then compound 3; then compound 2.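

In this assay, going by these compounds alone, the first change at this amine nitrogen gives a 1.1-fold lower number from compound 1 to compound 4 (0.02 log units; within the scatter), so (2,4,6-trimethylphenyl)carbonyl matches (2,4,6-trimethylphenyl)sulfonyl here, despite having 1 hydrogen-bond acceptor against 2. The earlier steps shown here all concerned other parts of the molecule and said nothing about this nitrogen. No measurement available here explains this match. Still open, from the compounds shown here alone, is whether an acetyl group, with no aromatic ring, or a plain phenylsulfonyl group, without the three methyl groups, would hold the number at this nitrogen. Also open, going by these compounds, is whether the match persists on the cores of compound 2 and compound 3.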